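Chain length at the carbonate-side hydroxyalkyl group

The source may report more compounds than this note shows. Statements on the series, on what has been measured and on what is new or still open speak of the compounds shown alone.

Measured so far in an ADME assay on the whole organism (serum) with Homo sapiens as the target; on this read-out lower numbers stand for a shorter-lived compound and higher numbers for a longer-lived compound:
compound 1, `Cc1cn(C2CC(N=[N+]=[N-])C(COC(=O)OCCCCCCCCO)O2)c(=O)[nH]c1=O`: 0.0333 h
compound 2, `Cc1cn(C2CC(N=[N+]=[N-])C(COC(=O)OCCCO)O2)c(=O)[nH]c1=O`: 0.167 h
compound 3, `Cc1cn(C2CC(N=[N+]=[N-])C(COC(=O)NCCCC(=O)OC(C)(C)C)O2)c(=O)[nH]c1=O`: > 48 h

The value of compound 3 in this assay is a limit, not a number (the limit of > 48 h in this assay, at which 1 of the 3 values shown sits). Among the two numbers available, compound 2 stands highest; the nearest, compound 1, sits a 5.0-fold higher number from compound 1 to compound 2 (0.70 log units; beyond the scatter). Among the measured compounds shown here, that step, which sits beyond the scatter, is the only measured step that bears on the present change: it shortens the hydroxyalkyl chain on the shared core and the number rises.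

Compound 4 is `Cc1cn(C2CC(N=[N+]=[N-])C(COC(=O)OCCCCCCO)O2)c(=O)[nH]c1=O`. It differs from compound 2 in one place: 3-hydroxypropyl in place of hydroxy on a saturated chain carbon, three bonds along the chain from an oxygen next to a carbonyl group. The change runs in the direction opposite to the step from compound 1 to compound 2, lengthening the chain, though by fewer carbons than that step removed. A lower number in this assay is therefore expected for compound 4, of a size smaller than the measured step, and the chain length of compound 4 falls between those of compound 1 and compound 2.

Compound 4 is estimated at 0.07 h in this assay, within 0.03 h to 0.16 h. This estimate means a step of a 2.4-fold lower number from compound 2 to compound 4 (0.38 log units; beyond the scatter), expected to fall beyond the scatter.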

Compound 4, half-life: 0.117 h
For compound 4 the middle estimate is 1.7-fold (0.22 log units) below the measured one; the range from low to high includes it.
By their numbers in this assay, from the lowest: compound 1; then compounds 4 and 2 (each within the scatter of the next). At a limit, above all of these: compound 3.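

At this place, on a saturated chain carbon, three bonds along the chain from an oxygen next to a carbonyl group, 3-hydroxypropyl in place of hydroxy gives in this assay a 1.4-fold lower number from compound 2 to compound 4 (0.15 log units; within the scatter), so this lengthening does not separate the two compounds. The difference at the long end of the chain stays readable: hydroxy in place of 2-hydroxyethyl, six bonds along the chain from an oxygen next to a carbonyl group, gives a 3.5-fold higher number from compound 1 to compound 4 (0.55 log units; beyond the scatter). Among these three compounds, the readable part of the chain-length effect therefore lies in the stretch from compound 1 to compound 4 and not in the stretch from compound 4 to compound 2, and nothing at hand gives a cause for this shape.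

Compound 3 stands apart with a value that is a limit, not a number: the limit of > 48 h in this assay, at which 1 of the 4 values shown sits. Still open, going by these compounds, is how this assay responds to a chain longer than that of compound 1, or to an amine or a carboxylic acid in place of the hydroxy at the chain end.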